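From thiophen-2-yl to furan-2-yl on a shared core

The source may hold more compounds than are shown below. What is called first, only, known or untested is meant among the compounds shown, and "the series" means these compounds.

Values so far in an ADME assay on RAW264.7 cells (Mus musculus) for cytotoxicity, read by MTT assay (a higher number here means a weaker inhibitor, a lower number a stronger inhibitor), for the four compounds:
- Compound 1 `COc1ccc(/C=C/C=C/C(=O)c2cc(C)oc2C)cc1` gives > 100000 nM as a limit of the assay
- Compound 2 `COc1ccc(/C=C/C=C/C(=O)c2cc(C)sc2C)cc1` stands at "not determined" (no result reported) with no result reported
- Compound 3 `COc1ccc(/C=C/C=C/C(=O)c2cccs2)cc1` gives 68500 nM as a plain number
- Compound 4 `COc1ccc(/C=C/C=C/C(=O)c2ccco2)cc1` has no measurement yet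

Going by the values given here, compound 3 holds the only actual number in this assay so far, while compound 1 sits at a limit and compound 2 has no result. The change to compound 4 is furan-2-yl in place of thiophen-2-yl on a carbonyl carbon and amounts to furan-2-yl in place of thiophen-2-yl on a carbonyl carbon. A single measured step bears on this change, namely an at least 1.4-fold lower number from compound 1 to compound 3 (0.16 log units; that floor lies within the scatter) and it starts from a limit. No step beyond the scatter is therefore expected in this assay in either direction. The expected step is a 1.1-fold higher number from compound 3 to compound 4 (0.04 log units; within the scatter) and it stays within the scatter. Compound 4 is estimated at 75000 nM with 40000 nM to 130000 nM as its expected range.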

Compound 4, half-maximal inhibitory concentration: 76600 nM
For compound 4 the middle estimate is 1.0-fold (0.01 log units) below the measured one; low and high end bracket the measured number.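

In this assay, going by these compounds alone, furan-2-yl in place of thiophen-2-yl on the carbonyl carbon gives a 1.1-fold higher number from compound 3 to compound 4 (0.05 log units; within the scatter), the first step at this position between two plain numbers. The comparison with the 2,5-dimethylfuran-3-yl compound reads an at least 1.3-fold lower number from compound 1 to compound 4 (0.11 log units; that floor lies within the scatter). That is only a floor, because compound 1 stands at a limit of the assay: the limit of > 100000 nM in this assay, at which 1 of the 4 values shown sits.

The compounds shown leave open whether an amine or a longer chain in place of the five-membered aromatic ring would move the number beyond the scatter.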